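The source may hold more compounds than are shown below. What is called first, only, known or untested is meant among the compounds shown, and "the series" means these compounds.

In a functional assay (trachea) with Cavia porcellus as the target (a higher number here means that more compound is needed for the effect, a lower number that less compound is needed), compound 3 `CCCn1c(=O)n(C)c(=O)c2c1ncn2CCCN(C)C` stands at > 100000 nM, which is a limit of the assay and not a number. The other two measured compounds give numbers: compound 1 `C=CCCn1cnc2c1c(=O)n(C)c(=O)n2CCC` gives 16800 nM and compound 2 `CCCn1c(=O)n(C)c(=O)c2c1ncn2CC#N` gives 35300 nM.

The change to compound 4 `CCCn1c(=O)n(C)c(=O)c2c1ncn2CC(C)=O` is acetyl in place of 2-(dimethylamino)ethyl on a saturated chain carbon bound to an aromatic nitrogen.

Within the data shown here, three measured steps bear on this. Two of them end at compound 3 and so bring in the dimethylamino group that leaves here: an at least 5.9-fold higher number from compound 1 to compound 3 (0.77 log units; beyond the scatter), and an at least 2.8-fold higher number from compound 2 to compound 3 (0.45 log units; beyond the scatter). On these data alone, both are bounds, so their true size remains open. The third, a 2.1-fold higher number from compound 1 to compound 2 (0.32 log units; beyond the scatter), links two compounds without that group and is modest.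

Reading an at least 2.8-fold higher number from compound 2 to compound 3 (0.45 log units; beyond the scatter) backwards, a lower number of at least modest size is expected in this assay, with compound 4 landing in the region of compound 1 and compound 2 rather than at the limit. The expected change is an at least 3.3-fold lower number from compound 3 to compound 4 (0.52 log units; beyond the scatter). Among the measured compounds shown here, the acetyl group has no measured precedent, so the range stays wide. For compound 4 the estimate is 30000 nM, with an expected range from 10000 nM to 90000 nM.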

Compound 4, half-maximal effective concentration: 1900 nM
Estimate against measurement, compound 4: 16-fold (1.20 log units) above; the measured number lies below the stated range.
By their numbers in this assay, from the lowest: compound 4; then compound 1; then compound 2. At a limit, above all of these: compound 3.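

Acetyl in place of 2-(dimethylamino)ethyl on a saturated chain carbon bound to an aromatic nitrogen gives an at least 52-fold lower number from compound 3 to compound 4 (1.72 log units; beyond the scatter) in this assay, a much larger movement at this place than the earlier steps showed. The acetyl group also lies clearly under the two earlier side chains that gave numbers, with a 19-fold lower number from compound 2 to compound 4 (1.27 log units; beyond the scatter) against cyano and an 8.8-fold lower number from compound 1 to compound 4 (0.95 log units; beyond the scatter) against allyl, so the earlier numbers do not mark a floor for this place. Compound 3 stands at a limit and not at a number, so the true size of the first of these steps stays open: the limit of > 100000 nM in this assay, at which 1 of the 4 values shown sits.

With a single acetyl compound, the compounds shown do not tell whether the carbonyl or the short chain goes with the lower number, and a longer ketone chain, an amide or a carboxylic acid at the same place would bear on that question. On these data alone, it also remains open whether the lower number with acetyl holds when the propyl group elsewhere on the shared core is replaced by a longer chain.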